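Dropping Both Methoxy Groups from the Hydrazone Aryl Ring

The source may hold more compounds than are shown below. What is called first, only, known or untested is meant among the compounds shown, and "the series" means these compounds.

Going by the values given here, in a functional assay on U-87MG ATCC cells (Homo sapiens) for cytotoxicity, read by MTT assay, with a stated time of 72 h (on this read-out higher numbers stand for weaker inhibition and lower numbers for stronger inhibition), compound 2 `COc1ccc(/C=N/NC(=O)Nc2ccc(Oc3ccnc(-c4nncn4CCN(C)C)c3)c(F)c2)c(OC)c1` gives 12600 nM, the high end of the two numbers known here, yet within the scatter of compound 1 `Cc1cc(/C=N/NC(=O)Nc2ccc(Oc3ccnc(-c4nncn4CCN(C)C)c3)c(F)c2)cc(C)c1O`, which in this assay gives 7710 nM. Compound 3 `CN(C)CCn1cnnc1-c1cc(Oc2ccc(NC(=O)N/N=C/c3ccccc3)cc2F)ccn1` differs from compound 2 by phenyl in place of 2,4-dimethoxyphenyl on a carbon with a double bond to nitrogen. Among the compounds with values here, the one measured step at that carbon, a 1.6-fold higher number from compound 1 to compound 2 (0.21 log units; within the scatter), stayed within the scatter, so no step beyond the scatter in this assay is expected for compound 3 either. Compound 3 is therefore estimated at 12000 nM, with a range from 5000 nM to 30000 nM. That estimate means an expected step of a 1.1-fold lower number from compound 2 to compound 3 (0.02 log units; within the scatter) for compound 3.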

Compound 3, half-maximal inhibitory concentration: 2250 nM
The estimate for compound 3 lay 5.3-fold (0.73 log units) above the measured number; the whole stated range lies above it.
By their numbers in this assay, from the lowest: compound 3; then compounds 1 and 2 (each within the scatter of the next).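

In this assay, phenyl in place of 2,4-dimethoxyphenyl gives (a 5.6-fold lower number from compound 2 to compound 3 (0.75 log units; beyond the scatter)) and phenyl in place of 4-hydroxy-3,5-dimethylphenyl gives (a 3.4-fold lower number from compound 1 to compound 3 (0.53 log units; beyond the scatter)), so this position responds beyond the scatter, which the step between the two substituted rings did not show. Among these three compounds, the number is lowest with the ring that carries no substituent. Nothing available explains this change.

Going by these compounds, whether a single methoxy or methyl group would raise the number remains open. So does the effect of an amine or carboxylic acid on the phenyl ring.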